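Working notes: amino in place of fluoro, compound 4

The source may report more compounds than this note shows. Statements on the series, on what has been measured and on what is new or still open speak of the compounds shown alone.

In a functional assay on HeLa cells (Homo sapiens) for inhibition, read by CCK-8 assay, with a stated time of 48 h (on this read-out higher numbers stand for weaker inhibition and lower numbers for stronger inhibition), compound 1 `COc1cc(-c2ccnc3cc(-c4cccc(C#N)c4)nn23)cc(OC)c1OC` gives > 10000 nM, which is a limit of the assay and not a number. Compound 2 `COc1ccc(-c2cc3nccc(-c4cc(OC)c(OC)c(OC)c4)n3n2)cc1` gives 373 nM. Compound 3 `COc1ccc(-c2cc3nccc(-c4cc(OC)c(OC)c(OC)c4)n3n2)cc1F` gives 236 nM. Compound 3 therefore stands with compound 2, within the scatter of it, and both lie well away from the limit of compound 1. The steps away from that limit are large: an at least 26-fold lower number from compound 1 to compound 2 (1.42 log units; beyond the scatter) and an at least 42-fold lower number from compound 1 to compound 3 (1.62 log units; beyond the scatter). Both exchange the whole 3-cyanophenyl group, so they bear only loosely on a change of one group.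

The next compound is compound 4 `COc1ccc(-c2cc3nccc(-c4cc(OC)c(OC)c(OC)c4)n3n2)cc1N`, with amino in place of fluoro on an aromatic carbon, ortho to a methoxy group: amino in place of fluoro on an aromatic carbon. The closest measured change sits on that same carbon, fluoro in place of hydrogen, and it gives a 1.6-fold lower number from compound 2 to compound 3 (0.20 log units; within the scatter), which stays within the scatter. Within the data shown here, no measured compound carries the amino group, so the range is kept wide. The expected step in this assay is small and within the scatter, leaning towards a lower number: a 1.6-fold lower number from compound 3 to compound 4 (0.20 log units; within the scatter). Compound 4 is expected at 150 nM, with an estimated range of 30 nM to 600 nM.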

Compound 4, half-maximal inhibitory concentration: 283 nM
Estimate against measurement, compound 4: 1.9-fold (0.28 log units) below; the range from low to high includes it.
By their numbers in this assay, from the lowest: compounds 3, 4 and 2 (each within the scatter of the next). At a limit, above all of these: compound 1.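

In this assay, the carbon ortho to a methoxy group now carries hydrogen, fluoro or amino without any separation among the three compounds: a 1.2-fold higher number from compound 3 to compound 4 (0.08 log units; within the scatter), and a 1.3-fold lower number from compound 2 to compound 4 (0.12 log units; within the scatter). Amino enters with a hydrogen-bond donor and a hydrogen-bond acceptor where fluoro has neither, so on this read-out the position accepts that change in count with no step beyond the scatter, a statement that rests on compounds 2, 3 and 4 alone. The only large change remains the exchange of the whole aryl group, an at least 35-fold lower number from compound 1 to compound 4 (1.54 log units; beyond the scatter), and that step is only a bound, since compound 1 stands at a limit of the assay and not at a number: the limit of > 10000 nM in this assay, at which 1 of the 4 values shown sits.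

From the compounds shown here alone, whether this carbon would hold a larger group, such as an acetamide, a dimethylamino group or a carboxylic acid, with the number still in this range remains open. Also open, going by these compounds, is how much of the large step belongs to the nitrile and how much to the methoxy group, as compound 1 differs from the others in the whole aryl group.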